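Replacing 3-chloro-4-fluorobenzyl with propyl at the sulfur

The source may hold more compounds than are shown below. What is called first, only, known or untested is meant among the compounds shown, and "the series" means these compounds.

Measured in a toxicity assay on GES1 cells (Homo sapiens) for inhibition, read by MTT assay, with a stated time of 72 h; on this read-out lower numbers stand for stronger inhibition and higher numbers for weaker inhibition:
Compound 1 `Cc1cc(N2CC[C@@H](C)[C@@H](N(C)c3ncnc4[nH]ccc34)C2)n2nc(SCC3CC3)nc2n1`: 27900 nM
Compound 2 `Cc1cc(N2CC[C@@H](C)[C@@H](N(C)c3ncnc4[nH]ccc34)C2)n2nc(SCc3nc4ccccc4[nH]3)nc2n1`: 40200 nM
Compound 3 `Cc1cc(N2CC[C@@H](C)[C@@H](N(C)c3ncnc4[nH]ccc34)C2)n2nc(SCc3ccc(F)c(Cl)c3)nc2n1`: > 100000 nM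

Compound 3 stands at the limit of > 100000 nM in this assay, at which 1 of the 3 values shown sits, so its value is a limit and not a number. Compound 4 `CCCSc1nc2nc(C)cc(N3CC[C@@H](C)[C@@H](N(C)c4ncnc5[nH]ccc45)C3)n2n1` carries ethyl in place of 3-chloro-4-fluorophenyl on a saturated chain carbon bound to a sulfur. The measured steps that bear on this are an at least 3.5-fold higher number from compound 1 to compound 3 (0.55 log units; beyond the scatter), an at least 2.4-fold higher number from compound 2 to compound 3 (0.39 log units; beyond the scatter) and a 1.4-fold higher number from compound 1 to compound 2 (0.16 log units; within the scatter). The closest measured neighbour is compound 1, with cyclopropyl at that place and a value of 27900 nM. In this assay a move to a lower number is therefore expected, of about the size of the first step reversed, and the expected step is an at least 3.3-fold lower number from compound 3 to compound 4 (0.52 log units; beyond the scatter). For compound 4 the estimate is 30000 nM, with an expected range of 12000 nM to 80000 nM.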

Compound 4, half-maximal inhibitory concentration: 67100 nM
For compound 4 the middle estimate is 2.2-fold (0.35 log units) below the measured one; low and high end bracket the measured number.
By their numbers in this assay, from the lowest: compounds 1, 2 and 4 (each within the scatter of the next, the first and the last beyond it). At a limit, above all of these: compound 3.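

In this assay, the change from a ring to an open chain registers at this place: ethyl in place of cyclopropyl gives a 2.4-fold higher number from compound 1 to compound 4 (0.38 log units; beyond the scatter), whereas ethyl in place of 1H-benzimidazol-2-yl gives a 1.7-fold higher number from compound 2 to compound 4 (0.22 log units; within the scatter). Compound 3 is held at a limit, > 100000 nM, so ethyl in place of 3-chloro-4-fluorophenyl can be read only as a floor: an at least 1.4-fold lower number from compound 3 to compound 4 (0.17 log units; that floor lies within the scatter). Removing the ring at this place therefore does not bring the number back to that of compound 1.

The compounds shown leave open how a longer chain, an amine or a carboxylic acid would read on this saturated chain carbon bound to a sulfur. They also leave open how far compound 3 truly lies from the others.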